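The source may report more compounds than this note shows. Statements on the series, on what has been measured and on what is new or still open speak of the compounds shown alone.

Compound 2 `COc1ccc(-c2cc(COc3ccccc3-c3nc4ccccc4s3)on2)cc1` was tested in a functional assay on A549 cells (Homo sapiens) for cytotoxicity, read by MTT assay, with a stated time of 24 h (a lower number here means a stronger inhibitor, a higher number a weaker inhibitor), where compound 2 gives 24100 nM. Compound 1 `Fc1ccc(-n2cc(COc3ccccc3-c3nc4ccccc4s3)nn2)cc1` gives 23300 nM in the same assay; the two numbers lie within the usual scatter of each other, so compound 2 stands beside compound 1 rather than apart from it. Compound 3 `Cc1ccc(-c2cc(COc3ccccc3-c3nc4ccccc4s3)on2)cc1` has not yet been measured. It differs from compound 2 in one place: methyl in place of methoxy on an aromatic carbon. Nothing measured here shows what such a swap does, so for compound 3 the step of a 1.0-fold lower number from compound 2 to compound 3 (0.00 log units; within the scatter) is expected to stay within the scatter, in no clear direction. Compound 3 is estimated at 24000 nM, with a range from 10000 nM to 55000 nM.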

Compound 3, half-maximal inhibitory concentration: 16400 nM
For compound 3 the middle estimate is 1.5-fold (0.17 log units) above the measured one; measured number inside the range.
By their numbers in this assay, from the lowest: compounds 3, 1 and 2 (each within the scatter of the next).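

Going from 4-methoxyphenyl to 4-methylphenyl gives a 1.5-fold lower number from compound 2 to compound 3 (0.17 log units; within the scatter) in this assay. At this place, para to a large group, the methoxy oxygen with its one hydrogen-bond acceptor can therefore be removed without a clear shift in the number. No supporting data bear on why this step is so small. As far as these compounds go, what stays open is whether a group of another kind here, such as an amine, a carboxylic acid or a longer chain, would move the number beyond the scatter.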